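The source may hold more compounds than are shown below. What is called first, only, known or untested is meant among the compounds shown, and "the series" means these compounds.

Values in an assay on U2OS cells for inhibition of secreted frizzled-related protein 1 (Homo sapiens), read by a luciferase reporter, with a stated time of 18 h; a higher number here means that more compound is needed for the effect, a lower number that less compound is needed:
- compound 1 `CN(C)c1ccc(C(=O)N2CCC(NS(=O)(=O)c3cc(S(=O)(=O)c4ccccc4)ccc3C(F)(F)F)CC2)cc1`: 190 nM
- compound 2 `CN(C)c1ccc(C(=O)N2CCC(NS(=O)(=O)c3cc(S(=O)(=O)c4ccccc4)ccc3C(F)(F)F)CC2)cn1`: 70 nM
- compound 3 `O=S(=O)(NC1CCN(S(=O)(=O)c2ccccc2)CC1)c1cc(S(=O)(=O)c2ccccc2)ccc1C(F)(F)F`: 210 nM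

Compound 3 gives the highest of the three numbers in this assay; its nearest neighbour is compound 1, at a gap within the scatter, and the furthest is compound 2, a modest gap beyond the scatter.

Compound 4 `O=C(O)c1ccc(N2CCC(NS(=O)(=O)c3cc(S(=O)(=O)c4ccccc4)ccc3C(F)(F)F)CC2)cc1` is not yet measured. The change from compound 3 is 4-carboxyphenyl in place of phenylsulfonyl on an amine nitrogen in a ring.

Among the compounds with values here, the steps that bear on this site are the two that also swap the group on the amine nitrogen in the ring: a 1.1-fold higher number from compound 1 to compound 3 (0.04 log units; within the scatter) and a 3.0-fold higher number from compound 2 to compound 3 (0.48 log units; beyond the scatter). Both are small or modest, so this position has so far tolerated exchange of an aromatic carbonyl group for phenylsulfonyl with little change in this assay. Within the data shown here, compound 4 moves further, to an aromatic ring carrying a carboxylic acid and no carbonyl or sulfonyl link, which no measured pair covers, so the direction is open and the uncertainty is wider than the measured steps.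

Compound 4 is therefore expected to give about 320 nM in this assay, between 100 nM and 1000 nM, an estimated 1.5-fold higher number from compound 3 to compound 4 (0.18 log units; within the scatter).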

Compound 4, half-maximal effective concentration: 230 nM
For compound 4 the middle estimate is 1.4-fold (0.14 log units) above the measured one, within the range that was stated.
By their numbers in this assay, from the lowest: compound 2; then compounds 1, 3 and 4 (each within the scatter of the next).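

In this assay, the amine nitrogen in the ring now carries an aromatic ring with no carbonyl or sulfonyl link, and 4-carboxyphenyl cannot be told apart from phenylsulfonyl (a 1.1-fold higher number from compound 3 to compound 4 (0.04 log units; within the scatter)) or from (4-(dimethylamino)phenyl)carbonyl (a 1.2-fold higher number from compound 1 to compound 4 (0.08 log units; within the scatter)). The tolerance at this position therefore extends to a third kind of attachment and to a group bearing a carboxylic acid, with the exception of the (6-(dimethylamino)pyridin-3-yl)carbonyl group, which stays apart from 4-carboxyphenyl (a 3.3-fold higher number from compound 2 to compound 4 (0.52 log units; beyond the scatter)). No other measurement on these compounds bears on this result.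

The compounds shown do not separate the carboxylic acid from the directly attached aromatic ring, so an unsubstituted phenyl, a methyl ester or a primary amide on that ring would be needed to tell whether the acid contributes anything. Also open, going by these compounds, is whether a dimethylamino group or a pyridine ring nitrogen on the directly attached aromatic ring would give a number like that of compound 2 (70 nM).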